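Carboxy in place of methyl: next step in the series

The source may report more compounds than this note shows. Statements on the series, on what has been measured and on what is new or still open speak of the compounds shown alone.

Compound 1 `Cc1ccc(C)c2c(O)c(Cc3ccccc3)ccc12` gives 120 nM in an assay on RBL-1 cells with Polyunsaturated fatty acid 5-lipoxygenase (Rattus norvegicus) as the target; a higher number here means a weaker inhibitor, a lower number a stronger inhibitor.
Compound 2 `Cc1cc(Cc2ccccc2)c(O)c2ccccc12` gives 20 nM in this assay.

Compound 2 has the lowest number of the two; compound 1 differs from it in more than one place, and its higher number lies beyond the scatter. Compound 3 `O=C(O)c1cc(Cc2ccccc2)c(O)c2ccccc12` takes (carboxy in place of methyl on an aromatic carbon). Among the measured compounds shown here, no single-place step of this kind has been measured, so the expected direction rests on no precedent; a moderate rise is expected, with the step from compound 2 to compound 3 estimated at a 3.0-fold higher number from compound 2 to compound 3 (0.48 log units; beyond the scatter). Compound 3 is expected to give 60 nM in this assay, within a range of 15 nM to 300 nM.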

Compound 3, half-maximal inhibitory concentration: 5800 nM
The estimate for compound 3 lay 97-fold (1.99 log units) below the measured number, and the stated range ends below it.
By their numbers in this assay, from the lowest: compound 2; then compound 1; then compound 3.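

Among the compounds shown here, the aromatic carbon para to a hydroxy group is far from indifferent to its substituent: carboxy in place of methyl brings a 290-fold higher number from compound 2 to compound 3 (2.46 log units; beyond the scatter) in this assay and is the first single-place step read. Its size shows that this position does not accept every replacement of methyl. No measured property available here accounts for this step.

Open, on these data alone, is whether the rise belongs to the carboxy group alone or follows other replacements of methyl on this carbon. A methyl ester, an amide or an amine at the same place would separate these cases.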